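Solubility notes: benzothiazolylamino to thiadiazolylamino on the amide aryl

The source may report more compounds than this note shows. Statements on the series, on what has been measured and on what is new or still open speak of the compounds shown alone.

Measured so far:
Compound 1, `Cc1cc(C)n(-c2ccc(C(=O)NCC3(c4nc(-c5ccccc5)cs4)CCOCC3)cc2)n1`, in a physicochemical assay for solubility, read by chemiluminescence, in phosphate buffer, measured as kinetic solubility, at pH 7.4 (a higher number here means a more soluble compound, a lower number a less soluble compound), gives 33000 nM.
Compound 2, `O=C(NCC1(c2nc(-c3ccccc3)cs2)CCOCC1)c1ccc(CN2CCCCC2)cc1`, gives >= 396000 nM, which is a limit of the assay and not a number (the limit of >= 396000 nM in this assay, at which 1 of the 3 values shown sits).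
Compound 3, `O=C(NCC1(c2nc(-c3ccccc3)cs2)CCOCC1)c1ccc(Nc2nc3ccccc3s2)cc1`, gives 4000 nM.

Among the two plain numbers compound 3 stands lowest, and the step from compound 1 reads an 8.3-fold lower number from compound 1 to compound 3 (0.92 log units; beyond the scatter). Against the limit the step is an at least 99-fold lower number from compound 2 to compound 3 (1.99 log units; beyond the scatter). For comparison, an at least 12-fold higher number from compound 1 to compound 2 (1.07 log units; beyond the scatter).

Compound 4, `O=C(NCC1(c2nc(-c3ccccc3)cs2)CCOCC1)c1ccc(Nc2nncs2)cc1`, has not been measured. It differs from compound 3 in one place: 1,3,4-thiadiazol-2-yl in place of 1,3-benzothiazol-2-yl on a nitrogen on an aromatic ring. Within the data shown here, the steps that bear on this are those that introduce the (1,3-benzothiazol-2-yl)amino group, namely an 8.3-fold lower number from compound 1 to compound 3 (0.92 log units; beyond the scatter) and an at least 99-fold lower number from compound 2 to compound 3 (1.99 log units; beyond the scatter); both reached compound 3 with a lower number. The change to compound 4 removes part of that group while keeping the amino link, so a partial reversal toward compound 1 is expected rather than a further fall. The step is therefore estimated as a 3.0-fold higher number from compound 3 to compound 4 (0.48 log units; beyond the scatter), an increase of modest size in this assay. Compound 4 is expected to give 12000 nM, within the range 4000 nM to 40000 nM.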

Compound 4, solubility: 29000 nM
The estimate for compound 4 lay 2.4-fold (0.38 log units) below the measured number, within the range that was stated.
By their numbers in this assay, from the lowest: compound 3; then compounds 4 and 1 (each within the scatter of the next). At a limit, above all of these: compound 2.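

With 1,3,4-thiadiazol-2-yl in place of 1,3-benzothiazol-2-yl on a nitrogen on an aromatic ring, this assay shows a 7.3-fold higher number from compound 3 to compound 4 (0.86 log units; beyond the scatter); the amino link is present in both compounds, so that link alone does not hold the number at the level of compound 3. The step to the pyrazole compound sets (1,3,4-thiadiazol-2-yl)amino and 3,5-dimethyl-1H-pyrazol-1-yl on an aromatic carbon level in this series, with a 1.1-fold lower number from compound 1 to compound 4 (0.06 log units; within the scatter). The step from the (piperidin-1-yl)methyl compound, an at least 13-fold lower number from compound 2 to compound 4 (1.13 log units; beyond the scatter), is read against a limit of compound 2 and not against a number: the limit of >= 396000 nM in this assay, at which 1 of the 4 values shown sits.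

Still open, from the compounds shown here alone, is how an ether oxygen or a methylene in place of the amino link would read with the 1,3,4-thiadiazol-2-yl kept, and how a plain phenyl or a pyridine on that nitrogen would compare. Also open, going by these compounds, is whether a morpholine or a dimethylamino group in place of the piperidine would give a plain number or a limit, as compound 2 does.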